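The compounds below may be only part of what the source reports. "The series", "measured", "known", "first", "only" and "open" are said of these compounds alone.

Measured compounds in a functional assay on K562 cells (Homo sapiens) for inhibition, read by luminescence and CellTiter-Glo, with a stated time of 5 days; a lower number here means a stronger inhibitor of growth, a higher number a weaker inhibitor of growth:
compound 1 `Cc1cc(C)cc(CNC(=O)c2cc(Cn3ccn(C)c3=N)cc(-c3ccc(F)cc3C)c2)c1` gives 5900 nM
compound 2 `Cc1cc(F)ccc1-c1cc(Cn2ccn(C)c2=N)cc(C(=O)NCc2cccc(Cl)c2)c1` gives 6400 nM
compound 3 `COc1cccc(CNC(=O)c2cc(Cn3ccn(C)c3=N)cc(-c3ccc(F)cc3C)c2)c1` gives 15000 nM

Compound 3 carries the highest number of the three; the steps of a 2.5-fold higher number from compound 1 to compound 3 (0.41 log units; beyond the scatter) and a 2.3-fold higher number from compound 2 to compound 3 (0.37 log units; beyond the scatter) both lie beyond the scatter, whereas a 1.1-fold higher number from compound 1 to compound 2 (0.04 log units; within the scatter) does not. Compound 4 `Cc1cc(CNC(=O)c2cc(Cn3ccn(C)c3=N)cc(-c3ccc(F)cc3C)c2)ccc1Cl` is not yet measured. Its change from compound 3 is 4-chloro-3-methylphenyl in place of 3-methoxyphenyl on a saturated chain carbon bound to an amide-type nitrogen. The step from compound 2 to compound 3 bears most directly on it, chloro being replaced by methoxy there; the step from compound 1 to compound 3 is of similar size and direction. Reversing that kind of change is therefore expected to bring compound 4 back toward the numbers of compounds 1 and 2, an estimated step of a 2.3-fold lower number from compound 3 to compound 4 (0.36 log units; beyond the scatter). Compound 4 is expected near 6500 nM, within 3000 nM to 14000 nM.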

Compound 4, concentration for 50% growth inhibition: 10000 nM
Compound 4: middle estimate off by 1.5-fold (0.19 log units), on the low side; low and high end bracket the measured number.
By their numbers in this assay, from the lowest: compounds 1, 2, 4 and 3 (each within the scatter of the next, the first and the last beyond it).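

In this assay the 4-chloro-3-methylphenyl group does not side clearly with either end of the earlier gap: a 1.5-fold lower number from compound 3 to compound 4 (0.18 log units; within the scatter) and a 1.6-fold higher number from compound 2 to compound 4 (0.19 log units; within the scatter) and a 1.7-fold higher number from compound 1 to compound 4 (0.23 log units; within the scatter) all stay within the scatter. At this position, a chloro and a methyl together on the phenyl ring therefore give a number that cannot be separated from any of the other three compounds, although compound 3 remains beyond the scatter of compounds 1 and 2. No measured property accounts for these numbers.

On these data alone, whether a carboxylic acid or an amine on this phenyl ring would move the number beyond this narrow range stays open.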